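The compounds below may be only part of what the source reports. "The series", "measured", "known", "first", "only" and "open" are said of these compounds alone.

Measured compounds:
compound 1 `COc1cc(/C=C/C(=O)c2cccc(-n3cc(-c4ccc(Cl)cc4)[nH]c3=O)c2)ccc1O` — 1950 nM
compound 2 `COc1cc(/C=C/C(=O)c2cccc(-n3cc(-c4ccccc4)[nH]c3=O)c2)cc(OC)c1OC` — 3260 nM

In a functional assay on PC-3 cells (Homo sapiens) for inhibition (a higher number here means a weaker inhibitor of growth, a lower number a stronger inhibitor of growth), compound 1 gives 1950 nM, the lowest of the two numbers shown. Its nearest neighbour is compound 2, which in this assay gives 3260 nM; the gap between these two values lies within the scatter of repeated measurements, so the pair gives no ground for ranking one over the other. Among the measured compounds shown here, compound 2 also differs from compound 1 in more than one place, so no single step between them can be named.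

Compound 3 `COc1cc(/C=C/C(=O)c2cccc(-n3cc(-c4ccccc4)[nH]c3=O)c2)ccc1O` has not yet been measured in this assay. Its structure differs from that of compound 1 in a single place: hydrogen in place of chloro on an aromatic carbon. For the measured compounds named here, no measured pair shows the effect of this change here. Given the narrow spread of the two known values, the step from compound 1 to compound 3 is expected to be small, with no direction that clearly exceeds the scatter, so a 1.3-fold higher number from compound 1 to compound 3 (0.12 log units; within the scatter) is the expected step. Compound 3 is therefore estimated at 2600 nM in this assay, with an expected range from 1000 nM to 7000 nM.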

Compound 3, concentration for 50% growth inhibition: 2520 nM
Compound 3: middle estimate off by 1.0-fold (0.01 log units), on the high side; the measured number falls inside the stated range.
By their numbers in this assay, from the lowest: compounds 1, 3 and 2 (each within the scatter of the next).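

Among the compounds shown here, the step of a 1.3-fold higher number from compound 1 to compound 3 (0.11 log units; within the scatter) is the first single-place comparison in this assay, and it lies within the scatter. With the rest of the structure held the same, hydrogen in place of chloro on this aromatic carbon, para to a large group, leaves no readable difference in growth inhibition, so the 4-chlorophenyl group is not needed here for a number of this size. No measured property bears on this result, so the data give no explanation for how closely the two compounds read.

The compounds shown compare only hydrogen and chloro at this place, so it stays open whether a methoxy group, an amine or a carboxylic acid there would shift the number. For the compounds shown here, they also offer no single-place step that isolates the hydroxyl group of compound 3.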